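The compounds below may be only part of what the source reports. "The series", "measured", "known", "first", "only" and "open" are said of these compounds alone.

In a functional assay on HEK293 cells (Homo sapiens) for cytotoxicity (a higher number here means that more compound is tolerated, a lower number that less compound is tolerated), compound 1 (`COc1ccc([C@H]2CC(=O)N(Cc3cccc(N)c3)C2)cc1OC1CCCC1`) gives > 10000 nM as a limit of the assay and not as a number. Compound 2 (`COc1ccc([C@H]2CC(=O)N(Cc3cccc([N+](=O)[O-])c3)C2)cc1OC1CCCC1`) gives > 10000 nM as a limit too. Compound 3 (`COc1ccc([C@H]2CC(=O)N(c3cccc(N(C)C)c3)C2)cc1OC1CCCC1`), where this step begins, gives > 10000 nM as a limit as well, so it has no exact value and cannot be ranked against the other two.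

Compound 4 (`COc1ccc([C@H]2CC(=O)N(c3ccc(C)c(N)c3)C2)cc1OC1CCCC1`) has not been measured yet. It carries 3-amino-4-methylphenyl in place of 3-(dimethylamino)phenyl on an amide-type nitrogen in a ring.

Two measured steps change the group at that same place (a step that the two limits leave unreadable from compound 1 to compound 3 and a step that the two limits leave unreadable from compound 2 to compound 3), and a third (a step that the two limits leave unreadable from compound 1 to compound 2) puts nitro in place of amino on an aromatic carbon. None of the three has a size that can be read, and none shows a direction.

The expectation rests on the limit shared by compound 1, compound 2 and compound 3 (the limit of > 10000 nM in this assay, at which 3 of the 3 values shown sit): no step beyond the usual scatter is expected in this assay, and no direction can be named. The estimated outcome is a step that the limit leaves unreadable from compound 3 to compound 4 and another limit is the likeliest report. For compound 4 the estimate is 15000 nM with 6000 nM and 40000 nM as the expected ends of its range.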

Compound 4, half-maximal cytotoxic concentration: > 10000 nM
Compound 4 ended at the assay's limit; the forecaster's own chance of this, stated with the estimate: 85%; the middle value is on the limit's open side.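

In this assay compound 4 gives > 10000 nM, which is a limit of the assay and not a number. Its steps from compound 1, compound 2 and compound 3 cannot be read, since all four compounds share that limit: the limit of > 10000 nM in this assay, at which 4 of the 4 values shown sit. The compounds shown leave open how much of any of them the cells would tolerate, and whether changing the group on the amide-type nitrogen alters that.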